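Fluorophenyl swap on the shared core

The compounds below may be only part of what the source reports. "The series", "measured", "known", "first", "only" and "open" are said of these compounds alone.

Measured compounds:
compound 1 `COc1cc2c(Oc3ccc(NC(=O)c4nn(-c5cccc(F)c5)c(=O)c5ccccc45)cc3F)ccnc2cc1OCCCN1CCCC1` 160 nM
compound 2 `COc1cc2c(Oc3ccc(NC(=O)c4nn(-c5ccc(F)cc5)c(=O)c5ccccc45)cc3F)ccnc2cc1OCCCN1CCC(C)CC1` 130 nM

In a functional assay on MKN-45 cells (Homo sapiens) for cytotoxicity, read by MTT assay, with a stated time of 72 h (a higher number here means a weaker inhibitor, a lower number a stronger inhibitor), compound 2 gives the lower of the two numbers, yet compound 1 sits within the scatter of it, so the two cannot be ranked. Compound 3 `COc1cc2c(Oc3ccc(NC(=O)c4nn(-c5cccc(F)c5)c(=O)c5ccccc45)cc3F)ccnc2cc1OCCCN1CCC(C)CC1` is not yet measured. It differs from compound 2 by 3-fluorophenyl in place of 4-fluorophenyl on an aromatic nitrogen. Among the compounds with values here, no pair of measured compounds isolates this change, so no size can be read from the data. With both measured values so close together, the step from compound 2 to compound 3 in this assay is expected to stay within the scatter, a 1.1-fold higher number from compound 2 to compound 3 (0.03 log units; within the scatter). Compound 3 is therefore estimated at 140 nM, between 70 nM and 280 nM.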

Compound 3, half-maximal inhibitory concentration: 220 nM
For compound 3 the middle estimate is 1.6-fold (0.20 log units) below the measured one, within the range that was stated.
By their numbers in this assay, from the lowest: compounds 2, 1 and 3 (each within the scatter of the next).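

In this assay, 3-fluorophenyl in place of 4-fluorophenyl on the aromatic nitrogen now has a size (a 1.7-fold higher number from compound 2 to compound 3 (0.23 log units; within the scatter)), so this change, seen with the 4-methylpiperidin-1-yl chain end, does not separate the two compounds. 4-Methylpiperidin-1-yl in place of pyrrolidin-1-yl on the saturated chain carbon likewise leaves its pair unranked (a 1.4-fold higher number from compound 1 to compound 3 (0.14 log units; within the scatter)). Nothing measured here accounts for either step. As far as these compounds go, whether an unsubstituted phenyl or a chlorophenyl on that nitrogen, or a morpholin-4-yl at the chain end, would give a step beyond the scatter remains open.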